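Xanthate in place of the ring carboxy group

The source may hold more compounds than are shown below. What is called first, only, known or untested is meant among the compounds shown, and "the series" means these compounds.

Two compounds of this carbocyclic series have numbers in a functional assay on MCF7 cells (Homo sapiens) for antiproliferative activity, read by MTT assay, with a stated time of 48 h; on this read-out lower numbers stand for stronger inhibition and higher numbers for weaker inhibition. Compound 1, `C=C1/C=C/C(=O)/C(CO)=C\C[C@](C)(CCC=C(C)C)/C=C/[C@H]1OC(=O)C=C(C)C`, gives 2750 nM. Compound 2, `CC(C)=CCC[C@]1(C)/C=C/[C@@H](OC(=O)C=C(C)C)[C@](C)(O)/C=C/C(=O)/C(C(=O)O)=C\C1`, gives 16100 nM, the highest of the two numbers; its nearest neighbour is compound 1, which stands beyond the scatter from it.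

The next step goes from compound 2 to compound 3, `CSC(=S)OC/C1=C/C[C@](C)(CCC=C(C)C)/C=C/[C@@H](OC(=O)C=C(C)C)[C@](C)(O)/C=C/C1=O`. The change is a group of 6 heavy atoms (3 carbon, 1 oxygen, 2 sulfur; no ring) in place of a group of 3 heavy atoms (1 carbon, 2 oxygen; no ring), on a double-bonded ring carbon. Among the compounds with values here, no step between two measured compounds mirrors this change, so the expectation rests on the position of compound 2 alone and on the fact that the only other measured member, compound 1, which carries no carboxy group, gives the lower number.

For compound 3 the estimate in this assay is 4000 nM, with a range from 1500 nM to 12000 nM. The step this estimate means, a 4.0-fold lower number from compound 2 to compound 3 (0.60 log units; beyond the scatter), is expected to lie beyond the scatter, toward a lower number.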

Compound 3, half-maximal inhibitory concentration: 900 nM
Compound 3: middle estimate off by 4.4-fold (0.65 log units), on the high side; measured number outside the range, below it.
By their numbers in this assay, from the lowest: compound 3; then compound 1; then compound 2.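

At this double-bonded ring carbon, the carboxy group is not needed for activity in this assay: exchanging it for the xanthate gives an 18-fold lower number from compound 2 to compound 3 (1.25 log units; beyond the scatter), a large step. The change removes the only hydrogen-bond donor of the leaving group, adds two sulfur atoms and lengthens the substituent to 6 heavy atoms, while neither group carries a net charge, so several differences travel together in this single step. No measurement available here ties the step to any one of these differences or gives its cause.

A methyl ester, a primary amide or a methyl carbonate, the all-oxygen counterpart of the xanthate, at this carbon would help separate loss of the carboxy group from the presence of sulfur. On these data alone, how far a longer chain on the sulfur would carry the trend also remains open.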